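The source may report more compounds than this note shows. Statements on the series, on what has been measured and on what is new or still open speak of the compounds shown alone.

Measured so far in a functional assay on MCF7 cells (Homo sapiens) for antiproliferative activity; on this read-out higher numbers stand for weaker inhibition and lower numbers for stronger inhibition:
- Compound 1 `CC(=O)Oc1ccc(C(=O)Nc2cc3ccc(OCC4CCCNC4)c(C)c3oc2=O)cc1CC=C(C)C`: 820 nM
- Compound 2 `CC(C)=CCc1cc(C(=O)Nc2cc3ccc(OCC4CCCN(C)C4)c(C)c3oc2=O)ccc1O`: 2640 nM

Compound 2 has the higher of the two numbers, 2640 nM, and so the weaker inhibition. Compound 1 stands lower at 820 nM, a gap beyond the usual scatter of repeated measurements.

Compound 3 `CC(C)=CCc1cc(C(=O)Nc2cc3ccc(OCC4CCCNC4)c(C)c3oc2=O)ccc1O` has not yet been measured in this assay. It departs from compound 2 in a single place: hydrogen in place of methyl on an amine nitrogen in a ring. In plain words, hydrogen takes the place of methyl on an amine nitrogen in a ring, so that (1-methylpiperidin-3-yl)methoxy becomes (piperidin-3-yl)methoxy.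

For the measured compounds named here, no measured pair shows this change on its own, so the data give no direct size for it. The only other reference point is compound 1 at 820 nM, and the expectation leans towards that number without reaching it. A modest move to a lower number is therefore expected, though it may not clear the scatter. The expected size of the change is a 1.8-fold lower number from compound 2 to compound 3 (0.25 log units; within the scatter). The estimate for compound 3 is 1500 nM, with an expected range from 600 nM to 3500 nM.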

Compound 3, half-maximal inhibitory concentration: 790 nM
Compound 3: middle estimate off by 1.9-fold (0.28 log units), on the high side; low and high end bracket the measured number.
By their numbers in this assay, from the lowest: compounds 3 and 1 (each within the scatter of the next); then compound 2.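

In this assay the step from (1-methylpiperidin-3-yl)methoxy to (piperidin-3-yl)methoxy, with hydrogen in place of methyl on the amine nitrogen in the ring, is a 3.3-fold lower number from compound 2 to compound 3 (0.52 log units; beyond the scatter) and gives the first direct size for this change. The other new step, with hydrogen in place of acetyl on an oxygen on an aromatic ring, is a 1.0-fold lower number from compound 1 to compound 3 (0.02 log units; within the scatter) and shows that, with hydrogen on the ring nitrogen, the numbers for the acetyl and hydrogen forms cannot be told apart in this assay. No accompanying measurement bears on what lies behind either step.

The compounds shown cover only hydrogen and methyl on the ring nitrogen, leaving open how an ethyl group, a longer chain or an acetyl group at that place would read. They also leave open whether the methyl-to-hydrogen step keeps its size when the oxygen on the aromatic ring carries acetyl, or on a core with a different group in place of the 3-methylbut-2-enyl chain.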